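A few compounds are considered here, and "the series" means these few. Any claim that something is new, unique, unknown or untested is made for them only; others in the source may bear on it.

Measured so far:
compound 1 `O=C(O)c1cc(-c2cccc(COc3ccc4c(=O)n(CC5CC5)sc4c3)c2)ccc1Cl` — 2480 nM
compound 2 `O=C1c2ccc(OCc3cccc(-c4ccccc4)c3)cc2CN1C1CCCC1` — > 5000 nM

In an assay on HEK293 cells for positive allosteric modulation of metabotropic glutamate receptor 2 (Rattus norvegicus), read by thallium flux (a higher number here means that more compound is needed for the effect, a lower number that less compound is needed), compound 1 gives 2480 nM. For compound 2 the assay reports only a limit, > 5000 nM, so compound 2 sits at the limit of > 5000 nM in this assay, at which 1 of the 2 values shown sits, and has no number of its own. Compound 3 `O=C(O)c1ccc(Cl)c(-c2cccc(COc3ccc4c(c3)CN(C3CCCC3)C4=O)c2)c1` differs from compound 2 by 5-carboxy-2-chlorophenyl in place of phenyl on an aromatic carbon. Compound 1 carries the same 5-carboxy-2-chlorophenyl on another core and gives 2480 nM. On that basis a step toward lower values in this assay, beyond the scatter, is expected: an at least 1.6-fold lower number from compound 2 to compound 3 (0.22 log units; that floor lies within the scatter). Compound 3 is accordingly estimated at 3000 nM, within 800 nM to 12000 nM.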

Compound 3, half-maximal effective concentration: 90 nM
Compound 3: the middle estimate sits 33-fold (1.52 log units) above what was measured; the whole stated range lies above it.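

In this assay, 5-carboxy-2-chlorophenyl in place of phenyl on this aromatic carbon, meta to a large group, gives an at least 55-fold lower number from compound 2 to compound 3 (1.74 log units; beyond the scatter), so the number responds strongly to a change at this position on the shared core. Compound 1 carries the same group but has no partner here that differs from it in one place. The step is a floor, as compound 2 has only a limit: the limit of > 5000 nM in this assay, at which 1 of the 3 values shown sits.

The carboxylic acid and the chlorine enter together, and the compounds shown do not separate them. As far as these compounds go, whether a carboxyphenyl without chlorine, a chlorophenyl without the carboxylic acid, or a tetrazole in place of the carboxylic acid would keep the low number remains open.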